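Ester series: replacing the naphthyl arm of compound 3

A few compounds are considered here, and "the series" means these few. Any claim that something is new, unique, unknown or untested is made for them only; others in the source may bear on it.

Of the compounds shown here, three have been measured in an ADME assay on BJ cells (Homo sapiens) for cytotoxicity, read by CellTiter-Glo and resazurin assay, with a stated time of 72 h; on this read-out higher numbers stand for an effect only at larger amounts of compound and lower numbers for an effect already at smaller amounts. Compound 1 `CC(C)N(Cc1cccc(OCCCCCC(=O)O)c1)C(=O)c1ccc(-c2cccc3ccccc23)cc1` gives < 1.3 nM in this assay, which is a limit of the assay rather than a number. Compound 2 `CC(C)N(Cc1cccc(OCCCCCC(=O)O)c1)C(=O)c1ccc(-c2ccc3cc[nH]c3c2)cc1` gives > 26000 nM in this assay, also a limit. Compound 3 `CCOC(=O)CCCCCOc1cccc(CN(C(=O)c2ccc(-c3cccc4ccccc34)cc2)C(C)C)c1` gives > 26000 nM in this assay, again a limit. The two steps out of compound 1 are both large: an at least 20000-fold higher number from compound 1 to compound 2 (4.30 log units; beyond the scatter) and an at least 20000-fold higher number from compound 1 to compound 3 (4.30 log units; beyond the scatter). For the measured compounds named here, compound 3 thus stands at the upper end of the range covered so far, sharing that position with one other compound (the limit of > 26000 nM in this assay, at which 2 of the 3 values shown sit), while the lower limit is held by only one compound (the limit of < 1.3 nM in this assay, at which 1 of the 3 values shown sits).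

Compound 4 `CCOC(=O)CCCCCOc1cccc(CN(C(=O)c2ccc(-c3cccc(OCC(C)C)c3)cc2)C(C)C)c1` differs from compound 3 in one place: 3-(isobutoxy)phenyl in place of naphthalen-1-yl on an aromatic carbon. The measured step that bears on this is the removal of naphthalen-1-yl from the same aromatic carbon between compound 1 and compound 2, where the number rose beyond the scatter an at least 20000-fold higher number from compound 1 to compound 2 (4.30 log units; beyond the scatter). Since compound 3 already sits at the upper limit, any further rise cannot be resolved, and no step beyond the scatter is expected: a number no higher from compound 3 to compound 4 (the limit leaves the size open). Compound 4 is therefore expected to give 26000 nM in this assay, within a range of 9000 nM to 60000 nM, most likely reported again as a limit.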

Compound 4, half-maximal effective concentration: > 26000 nM
Compound 4: only a limit was reported (the forecaster's own chance of this, stated with the estimate: 85%); the middle value sits exactly at the limit.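

For the compounds shown here, compound 3 and compound 4 are both reported only as limits at the same upper end of the read-out, so no step between them can be read. The compounds shown leave open whether 3-(isobutoxy)phenyl in place of naphthalen-1-yl changes the number at all in the ethyl esters, and how that replacement reads in the free acids.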